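Swapping One Group on an Amide-Type Nitrogen

This account rests on a few compounds, and the source may have more. Where it says the series, first, only, none or still open, it means among the compounds named here.

In a functional assay (strain AB) with Danio rerio as the target, read by microscopy, with a stated time of 1 h (on this read-out lower numbers stand for an effect already at smaller amounts and higher numbers for an effect only at larger amounts of compound), compound 1 (`CCN1CCc2c(sc(NC(=O)NCC3CCCO3)c2C(N)=O)C1`) gives > 25000 nM, which is a limit of the assay and not a number. Compound 3 (`CCN1CCc2c(sc(NC(=O)Nc3ccc(Cl)cc3)c2C(=O)OC)C1`) gives > 25000 nM, and this too is a limit. Compound 1 therefore sits at the limit of > 25000 nM in this assay, at which 2 of the 3 values shown sit, so any step away from it can only be judged roughly. Of the measured compounds, only compound 2 (`CC(C)(C)OC(=O)CCN1CCc2c(sc(NC(=O)Nc3ccc(Cl)cc3)c2C(N)=O)C1`) gives a true number, 1100 nM, and it carries an aromatic ring on the amide-type nitrogen.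

Compound 4 (`CCN1CCc2c(sc(NC(=O)Nc3ccc(I)cc3)c2C(N)=O)C1`) has not yet been measured. It keeps the core of compound 1 but has 4-iodophenyl in place of (oxolan-2-yl)methyl on an amide-type nitrogen. This brings in an aromatic ring at that place, as in compound 2 with its 1100 nM. Compound 3 goes against any simple rule, as it has such a ring too and still shows no number. A step toward smaller numbers, beyond the scatter, is expected in this assay, but with much uncertainty. The estimated size of the change is an at least 10-fold lower number from compound 1 to compound 4 (1.00 log units; beyond the scatter), though it may prove smaller. For compound 4 the expected value is 2500 nM, with an estimated range from 400 nM to 15000 nM.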

Compound 4, half-maximal effective concentration: 1620 nM
The estimate for compound 4 lay 1.5-fold (0.19 log units) above the measured number; the measured number falls inside the stated range.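

In this assay, the swap of 4-iodophenyl for (oxolan-2-yl)methyl on the amide-type nitrogen gives an at least 15-fold lower number from compound 1 to compound 4 (1.18 log units; beyond the scatter), and this is the only step shown between two compounds that differ in one place. For the compounds shown here, it shows directly what the earlier compounds could only suggest: with the rest of the core of compound 1 unchanged, the group on this nitrogen alone decides whether the assay returns a true number or only a limit. The real size of the step cannot be read, only its smallest possible size, because compound 1 gives a limit and not a number: the limit of > 25000 nM in this assay, at which 2 of the 4 values shown sit.

The compounds shown leave open whether the step comes from the aromatic ring or from the iodine, and a plain phenyl or a cyclohexyl on this nitrogen would separate the two. Compound 3, which also has an aromatic ring at this place, differs from compound 4 in more than one place, and what holds it at its own limit stays unresolved.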